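The source may hold more compounds than are shown below. What is called first, only, known or untested is meant among the compounds shown, and "the series" means these compounds.

Of the compounds shown here, two with a shared core have been tested in a functional assay on MOLT-4 cells (Homo sapiens) for antiproliferative activity; a lower number here means a stronger inhibitor of growth, a higher number a weaker inhibitor of growth. Compound 1 `CCOC(=O)C[C@H]1[C@@H](O[Si](C)(C)C(C)(C)C)[C@H](n2cnc3c(NC(=O)Nc4ccccc4)ncnc32)O[C@@H]1COC(=O)NC` gives 1.99 nM in this assay. Compound 2 `CNC(=O)NC[C@H]1O[C@@H](n2cnc3c(NC(=O)Nc4ccccc4)ncnc32)[C@H](O[Si](C)(C)C(C)(C)C)[C@@H]1CC(=O)N(C)OC` gives 2.23 nM, the higher of the two numbers, though the gap to compound 1 falls within the usual scatter. Compound 3 `CCOC(=O)C[C@H]1[C@@H](O[Si](C)(C)C(C)(C)C)[C@H](n2cnc3c(NC(=O)Nc4ccccc4)ncnc32)O[C@@H]1CNC(=O)NC` is not yet measured; it differs from compound 2 in a single place: ethoxy in place of methoxy(methyl)amino on a carbonyl carbon. Going by the values given here, no measured pair shows a change of this kind, so there is no direct comparison to lean on. Compound 3 is expected to give 2 nM, ranging from 1 nM to 4.5 nM. The expected step of a 1.1-fold lower number from compound 2 to compound 3 (0.05 log units; within the scatter) is small, with no direction beyond the scatter.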

Compound 3, concentration for 50% growth inhibition: 2.39 nM
The estimate for compound 3 lay 1.2-fold (0.08 log units) below the measured number; low and high end bracket the measured number.
By their numbers in this assay, from the lowest: compounds 1, 2 and 3 (each within the scatter of the next).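

Going by these compounds alone, replacing methoxy(methyl)amino with ethoxy on a carbonyl carbon gives in this assay a 1.1-fold higher number from compound 2 to compound 3 (0.03 log units; within the scatter) and is the first direct test of this change. Placing (methylcarbamoyl)amino where (methylcarbamoyl)oxy stood on a saturated chain carbon bound to a saturated ring carbon gives a 1.2-fold higher number from compound 1 to compound 3 (0.08 log units; within the scatter) and so shows that this second place can also change without a clear shift. Nothing available here explains these small steps. On these data alone, whether a carboxylic acid on that carbonyl carbon would behave the same remains open. So does the effect of a plain amine on that saturated chain carbon.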